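The source may report more compounds than this note shows. Statements on the series, on what has been measured and on what is new or still open speak of the compounds shown alone.

In a functional assay on HEK293 cells for agonist activity at Free fatty acid receptor 1 (Homo sapiens), read by fluorescence and calcium flux (on this read-out higher numbers stand for an effect only at larger amounts of compound and lower numbers for an effect already at smaller amounts), the measured set is:
compound 1 `CC#CC(CC(=O)O)c1ccc(OCc2ccc(C(=O)N3CCN(c4ccccn4)CC3)s2)cc1`: 138 nM
compound 2 `CC#CC(CC(=O)O)c1ccc(OCc2ccc(C(=O)N3CCN(c4ccc(OC)cc4)CC3)s2)cc1`: 289 nM
compound 3 `CC#CC(CC(=O)O)c1ccc(OCc2ccc(C(=O)N3CCN(c4cccc([N+](=O)[O-])c4)CC3)s2)cc1`: 187 nM

Compound 3 stands second highest of the three numbers in this assay; the steps that end at it are a 1.4-fold higher number from compound 1 to compound 3 (0.13 log units; within the scatter) and a 1.5-fold lower number from compound 2 to compound 3 (0.19 log units; within the scatter), both within the scatter, so no order among them is claimed. Compound 4 `CC#CC(CC(=O)O)c1ccc(OCc2ccc(C(=O)N3CCN(c4ccccc4[N+](=O)[O-])CC3)s2)cc1` differs from compound 3 by 2-nitrophenyl in place of 3-nitrophenyl on an amine nitrogen in a ring. Among the compounds with values here, no measured step moves the nitro group within the ring; the steps that exchange the whole aryl group are a 2.1-fold higher number from compound 1 to compound 2 (0.32 log units; beyond the scatter), the only one beyond the scatter, and the two within it. Because a 1.5-fold lower number from compound 2 to compound 3 (0.19 log units; within the scatter) lies within the scatter and the aryl exchanges stayed small, no step beyond the scatter is expected: a 1.1-fold higher number from compound 3 to compound 4 (0.03 log units; within the scatter). Compound 4 is estimated at 200 nM, range 90 nM to 450 nM.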

Compound 4, half-maximal effective concentration: 94 nM
The estimate for compound 4 lay 2.1-fold (0.33 log units) above the measured number, and the stated range covers the measured number.
By their numbers in this assay, from the lowest: compounds 4, 1, 3 and 2 (each within the scatter of the next, the first and the last beyond it).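

In this assay, within the data shown here, the first step that moves the nitro group within the ring is a 2.0-fold lower number from compound 3 to compound 4 (0.30 log units; within the scatter) and it stays within the scatter, so 2-nitrophenyl and 3-nitrophenyl are not separated. Exchanging 4-methoxyphenyl for 2-nitrophenyl gives a 3.1-fold lower number from compound 2 to compound 4 (0.49 log units; beyond the scatter) and this step lies beyond the scatter, as the exchange with pyridin-2-yl already did for compound 2. Exchanging pyridin-2-yl for 2-nitrophenyl gives a 1.5-fold lower number from compound 1 to compound 4 (0.17 log units; within the scatter) and this step stays within the scatter.

From the compounds shown here alone, whether a nitrile or a trifluoromethyl in place of the nitro group would keep the number of compound 4 stays open. No measurement here bears on the reason for these steps.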